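Nitro in Place of Methyl: Expected Cytotoxicity of Compound 3

The compounds below may be only part of what the source reports. "The series", "measured", "known", "first", "only" and "open" are said of these compounds alone.

Compound 1 `Clc1ccc(-c2csc(N/N=C/c3ccc(-n4cncn4)cc3)n2)c(Cl)c1` — 8.9%
Compound 2 `Cc1ccc(-c2csc(N/N=C/c3ccc(-n4cncn4)cc3)n2)cc1` — 13.6%

In an ADME assay on THP-1 cells (Homo sapiens) for cytotoxicity, read by MTT assay, tested at 50 ug/mL (a higher number here means more inhibition at the concentration tested (going by the name of the read-out), a lower number less inhibition), compound 1 gives 8.9% and compound 2 gives 13.6%. Compound 2 carries the upper of the two numbers, but the step of a number 4.7 percentage points higher from compound 1 to compound 2 (within the scatter) lies within the scatter, so on the numbers shown compound 2 cannot be told apart from compound 1; both sit at the low end of the inhibition scale.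

Compound 3 `O=[N+]([O-])c1ccc(-c2csc(N/N=C/c3ccc(-n4cncn4)cc3)n2)cc1` is the next compound, and it differs from compound 2 in one place: nitro in place of methyl on an aromatic carbon. Going by the values given here, the only measured step that bears on this position is a number 4.7 percentage points higher from compound 1 to compound 2 (within the scatter), in which one substituted phenyl replaced another on the same aromatic carbon without moving the number beyond the scatter. Nothing in the data suggests that a further change at this place would behave otherwise. The expected step of a number 0.4 percentage points higher from compound 2 to compound 3 (within the scatter) is therefore none beyond the scatter. Compound 3 is estimated at 14% in this assay, with a range from 3% to 30%.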

Compound 3, a percentage reported as inhibition, at one concentration (the size of the read-out at that concentration, not a potency): 12.9%
Estimate against measurement, compound 3: 1.1 percentage points above; the measured number falls inside the stated range.
By their numbers in this assay, from the lowest: compounds 1, 3 and 2 (each within the scatter of the next).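

Placing nitro where compound 2 carries methyl, on the aromatic carbon para to a large group, gives in this assay a number 0.7 percentage points lower from compound 2 to compound 3 (within the scatter) and thereby provides the first exchange of one group on an otherwise unchanged 4-substituted phenyl, since the earlier pair differed in a whole substitution pattern. Nitro has hydrogen-bond acceptors and methyl has none, yet this difference in the counted make-up of the two groups comes with no step beyond the scatter, and the change from 2,4-dichlorophenyl to 4-nitrophenyl, read as a number 4 percentage points higher from compound 1 to compound 3 (within the scatter), leaves the three compounds indistinguishable in this read-out. No measurement shown offers a reason for this flat result.

What the compounds leave open is whether any group on this carbon can move the number beyond the scatter, for instance an amine, a carboxylic acid or a longer alkyl chain such as butyl. Going by these compounds, it also remains open whether a change elsewhere on the shared core, such as replacing the triazole-bearing phenyl with an unsubstituted phenyl, would do so.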